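The source may hold more compounds than are shown below. What is called first, only, known or untested is meant among the compounds shown, and "the series" means these compounds.

Three compounds were measured in a functional assay on MDA-MB-468 cells (Homo sapiens) for inhibition, read by sulforhodamine B assay, with a stated time of 48 h; on this read-out higher numbers stand for weaker inhibition of growth and lower numbers for stronger inhibition of growth:
Compound 1, `COc1ccc(-c2cc(/C=C/C(=O)c3ccc(N)cc3)[nH]n2)cc1`, gives 2090 nM.
Compound 2, `COc1ccc(C(=O)/C=C/c2cc(-c3cc(OC)c(OC)c(OC)c3)n[nH]2)cc1OC`, gives 2180 nM.
Compound 3, `COc1ccc(-c2cc(/C=C/C(=O)c3ccc(N)cc3)[nH]n2)cc1OC`, gives 3480 nM.

Compounds 1 and 2 have different cores, and the difference between the two cores is not broken down here. Compound 3 arises from compound 1 by methoxy in place of hydrogen on an aromatic carbon, a change that gave a 1.7-fold higher number from compound 1 to compound 3 (0.22 log units; within the scatter). Compound 4, `COc1cc(C(=O)/C=C/c2cc(-c3cc(OC)c(OC)c(OC)c3)n[nH]2)cc(OC)c1OC`, is not yet measured; it arises from compound 2 by methoxy in place of hydrogen on an aromatic carbon. Its place differs from that in compound 3 in being also meta to a methoxy group, so this is the same kind of change rather than the same change. In this assay the expected step is a 1.5-fold higher number from compound 2 to compound 4 (0.18 log units; within the scatter), set beside the earlier one, because the expectation rests on a 1.7-fold higher number from compound 1 to compound 3 (0.22 log units; within the scatter). Compound 4 is therefore estimated at 3300 nM, with a likely range from 1500 nM to 7000 nM.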

Compound 4, concentration for total growth inhibition: 2480 nM
Beside the measured number, compound 4's estimate is 1.3-fold (0.12 log units) above it; low and high end bracket the measured number.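

In this assay, methoxy in place of hydrogen on an aromatic carbon gave a 1.1-fold higher number from compound 2 to compound 4 (0.06 log units; within the scatter). Set beside the earlier step on the core of compound 1, this step does not differ from it beyond the scatter: the same change on two cores in this assay, a 1.7-fold higher number (0.22 log units; within the scatter) from compound 1 to compound 3 and a 1.1-fold higher number (0.06 log units; within the scatter) from compound 2 to compound 4, 1.5-fold (0.17 log units) apart, within the scatter of two such steps. The change thus carried from one core to the other without a detectable difference, but it does not show that the change has a real effect on either core, as both steps lie within the scatter, and the two cores do not carry it at quite the same kind of place.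

The compounds shown leave open whether a hydroxyl or a chlorine in place of a methoxy group would shift the number beyond the scatter. Going by these compounds, whether the step would hold on a third core also remains open.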